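The compounds below may be only part of what the source reports. "The series", "measured", "known", "first", "only" and "open" are said of these compounds alone.

Working notes on the series.

Among the measured compounds shown here, the three compounds measured so far share one core and differ only in a single aromatic substituent. Compound 1 `O=C1/C(=C/c2ccccc2)CCc2c(O)cccc21` gives 115 nM in an assay on isolated protein for inhibition of Amine oxidase [flavin-containing] B (Homo sapiens), read by fluorescence and spectrophotometry, with a stated time of 20 min; a lower number here means a stronger inhibitor, a higher number a weaker inhibitor. Compound 2 `O=C1/C(=C/c2ccccc2)CCc2ccccc21` gives 115 nM in this assay, and compound 3 `O=C1/C(=C/c2ccccc2)CCc2ccc(O)cc21` gives 115 nM there as well. On these numbers compound 2 stands level with both neighbours: the step of no change at the digits printed from compound 1 to compound 2 (within the scatter) (hydrogen in place of hydroxy on an aromatic carbon) and the step of no change at the digits printed from compound 2 to compound 3 (within the scatter) (hydroxy in place of hydrogen on an aromatic carbon) both leave the half-maximal inhibitory concentration where it was. Across three compounds, then, the aromatic ring of the core has tolerated a hydroxy at two different places, and its removal, without any shift beyond the scatter.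

Compound 4 `Nc1ccc2c(c1)CC/C(=C\c1ccccc1)C2=O` has not yet been measured. It differs from compound 2 by amino in place of hydrogen on an aromatic carbon. The step from compound 2 to compound 3 is the one that bears on it most directly, a donor-and-acceptor group entering at the same place on the same ring, and that step was flat. For the measured compounds named here, no measured step shows any effect of a ring substituent here, so the expectation for this assay is a step of no size beyond the scatter, in either direction: no change at the digits printed from compound 2 to compound 4 (within the scatter) is the expected change from compound 2 to compound 4. Compound 4 is accordingly estimated at 115 nM, with a range from 50 nM to 280 nM, pending the measurement.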

Compound 4, half-maximal inhibitory concentration: 115 nM
Compound 4: middle estimate and measured number agree at the digits printed; low and high end bracket the measured number.
By their numbers in this assay, from the lowest: compounds 1, 2, 3 and 4 (each within the scatter of the next).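

The amino group of compound 4 gives no change at the digits printed from compound 2 to compound 4 (within the scatter) in this assay, so the result extends the flat picture to a group with nitrogen rather than oxygen as the entering atom. Its place, meta to a fused ring and para to a fused ring, is also not the one taken by the hydroxy of compound 1 or of compound 3, so a further aromatic carbon of the shared core now carries a substituent with no shift beyond the scatter. Compound 3 and compound 4 print the same value, although they differ in both the group and its place, and with compound 2 as the unsubstituted reference, neither the amino nor the hydroxy group has yet separated from hydrogen. No measurement on hand bears on why these compounds stay level, and the result stands as an observation only.

The compounds shown leave open whether anything larger at this carbon, such as a methoxy group, a carboxylic acid or a longer alkyl chain, would still leave the number in place. They also leave open whether a hydroxy group here, or an amino group at the places held by hydroxy in compound 1 and compound 3, would read the same.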